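From a Nitrophenyl to a Difluorophenyl Group

A few compounds are considered here, and "the series" means these few. Any claim that something is new, unique, unknown or untested is made for them only; others in the source may bear on it.

Compound 2 `Nc1scc(CN2CCN(c3ccc([N+](=O)[O-])cc3)CC2)c1C(=O)c1ccc(Cl)cc1` gives 2% in an assay on CHO cells for displacement of a labelled ligand from adenosine receptor A3 (Homo sapiens), read by scintillation counting, with a stated time of 120 min, tested at 10 uM; on this read-out higher numbers stand for more inhibition at the one concentration tested (going by the name of the read-out) and lower numbers for less inhibition. It stands level with compound 3 `Nc1scc(CN2CCN(c3ccncc3)CC2)c1C(=O)c1ccc(Cl)cc1`, which gives 2%, the two together being the highest of three numbers, while compound 1 `Nc1scc(CN2CCN(c3ccc(Cl)cc3Cl)CC2)c1C(=O)c1ccc(Cl)cc1` gives 0%. The steps among them are a number 2 percentage points higher from compound 1 to compound 2 (within the scatter), a number 2 percentage points higher from compound 1 to compound 3 (within the scatter) and no change at the digits printed from compound 2 to compound 3 (within the scatter). Compound 4 `Nc1scc(CN2CCN(c3cc(F)ccc3F)CC2)c1C(=O)c1ccc(Cl)cc1` differs from compound 2 by 2,5-difluorophenyl in place of 4-nitrophenyl on an amine nitrogen in a ring. All three measured steps exchange the group on that ring nitrogen, including a 2,4-dichlorophenyl in compound 1, and each stayed within the scatter, so the step expected in this assay, a number 1 percentage points lower from compound 2 to compound 4 (within the scatter), is none beyond the scatter. Compound 4 is therefore estimated at 1%, within a range of 0% to 10%.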

Compound 4, a percentage reported as inhibition, at one concentration (the size of the read-out at that concentration, not a potency): 2%
Compound 4: middle estimate off by 1 percentage points, on the low side; the measured number falls inside the stated range.
By their numbers in this assay, from the lowest: compounds 1, 2, 3 and 4 (each within the scatter of the next).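

In this assay, placing 2,5-difluorophenyl on the amine nitrogen in the ring gives no change at the digits printed from compound 2 to compound 4 (within the scatter), no change at the digits printed from compound 3 to compound 4 (within the scatter) and a number 2 percentage points higher from compound 1 to compound 4 (within the scatter). A phenyl ring carrying fluorine thus joins the nitro, chloro and pyridine groups, and all four compounds lie within the scatter of one another, so the reading does not separate any of these groups at this position. No other data bearing on this result are available. Going by these compounds, it remains open whether a group of another kind on that ring nitrogen, such as a benzyl group, an alkyl chain or a carboxylic acid, would change the reading.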